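The source may report more compounds than this note shows. Statements on the series, on what has been measured and on what is new or still open speak of the compounds shown alone.

Of the compounds shown here, two have been measured in a functional assay on BV-2 cells (Mus musculus) for inhibition, read by Griess assay, with stated times of 3 h and 24 h; a higher number here means a weaker inhibitor, a lower number a stronger inhibitor. Compound 1 `O=S(=O)(/C=C/c1ccc(O)c(O)c1)NCc1ccc(Cl)cc1` gives 13700 nM in this assay, and compound 2 `CC(=O)Oc1ccc(/C=C/S(=O)(=O)NCc2ccccc2)cc1OC(C)=O` gives 19500 nM. Compound 2 thus carries the higher of the two numbers, yet its gap to compound 1 lies within the usual scatter, so the two cannot be told apart. Compound 3 `COc1ccc(CNS(=O)(=O)/C=C/c2ccc(OC(C)=O)c(OC(C)=O)c2)cc1` has not yet been measured; it differs from compound 2 by methoxy in place of hydrogen on an aromatic carbon. For the measured compounds named here, no measured pair shows a comparable change, so no shift beyond the scatter is expected in this assay, and the step of a 1.1-fold lower number from compound 2 to compound 3 (0.03 log units; within the scatter) is estimated to be small. Compound 3 is expected to give about 18000 nM, within the range 8000 nM to 45000 nM.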

Compound 3, half-maximal inhibitory concentration: 26300 nM
Compound 3: middle estimate off by 1.5-fold (0.16 log units), on the low side; the measured number falls inside the stated range.
By their numbers in this assay, from the lowest: compounds 1, 2 and 3 (each within the scatter of the next).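

In this assay, for the compounds shown here, replacing benzyl with 4-methoxybenzyl gives a 1.3-fold higher number from compound 2 to compound 3 (0.13 log units; within the scatter) and is the first comparison here in which two compounds differ in only one place. At this position, para to a large group, the methoxy group therefore causes no shift that can be told from the scatter. No available evidence bears on this result. The compounds shown leave open whether a larger change here, such as an amine, a carboxylic acid or a longer chain, would also go without a clear shift.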